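The compounds below may be only part of what the source reports. "The series", "measured", "known", "first", "only" and "open" are said of these compounds alone.

Measured in an assay for inhibition of RAC-alpha serine/threonine-protein kinase (Homo sapiens), read by HTRF, with a stated time of 1 h; on this read-out lower numbers stand for stronger inhibition and higher numbers for weaker inhibition:
compound 1 `Cn1ncc(Cl)c1-c1cc(C(=O)N[C@@H]2CN[C@H](CCn3cncn3)C[C@H]2c2ccc(Cl)c(Cl)c2)oc1Cl` gives 4.47 nM
compound 2 `Cn1ncc(Cl)c1-c1cc(C(=O)N[C@@H]2CN[C@H](CC(=O)O)C[C@H]2c2ccc(Cl)c(Cl)c2)oc1Cl` gives 1.94 nM
compound 3 `C=CC[C@@H]1C[C@@H](c2ccc(Cl)c(Cl)c2)[C@H](NC(=O)c2cc(-c3c(Cl)cnn3C)c(Cl)o2)CN1` gives 12.4 nM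

Compound 3 stands highest of the three numbers: the nearest is compound 1, with a 2.8-fold higher number from compound 1 to compound 3 (0.44 log units; beyond the scatter), and the furthest is compound 2, with a 6.4-fold higher number from compound 2 to compound 3 (0.81 log units; beyond the scatter), both beyond the scatter. Compound 4 `Cn1ncc(Cl)c1-c1cc(C(=O)N[C@@H]2CN[C@H](CCO)C[C@H]2c2ccc(Cl)c(Cl)c2)oc1Cl` has not been measured; it differs from compound 3 by hydroxymethyl in place of vinyl on a saturated chain carbon bound to a saturated ring carbon. The two steps just named bear on this change, since in each the vinyl group, on entering in place of carboxy or (1H-1,2,4-triazol-1-yl)methyl, raised the number by a modest amount. Hydroxymethyl, bringing one hydrogen-bond donor and one hydrogen-bond acceptor, is therefore expected to lower the number in this assay by a modest step, a 2.8-fold lower number from compound 3 to compound 4 (0.44 log units; beyond the scatter). For compound 4 the estimate is 4.5 nM, within 1.8 nM to 12 nM.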

Compound 4, half-maximal inhibitory concentration: 2.74 nM
The estimate for compound 4 lay 1.6-fold (0.22 log units) above the measured number; the measured number falls inside the stated range.
By their numbers in this assay, from the lowest: compounds 2, 4 and 1 (each within the scatter of the next, the first and the last beyond it); then compound 3.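

In (this assay), hydroxymethyl in place of vinyl on this saturated chain carbon gave a clear gain (a 4.5-fold lower number from compound 3 to compound 4 (0.66 log units; beyond the scatter)) with no change in heavy-atom count, so that count alone does not set the number at this position. Compound 4 could not be separated from the carboxy compound (a 1.4-fold higher number from compound 2 to compound 4 (0.15 log units; within the scatter)) or the triazole compound (a 1.6-fold lower number from compound 1 to compound 4 (0.21 log units; within the scatter)). No measured evidence explains these results.

Going by these compounds, whether the hydrogen-bond donor is needed remains open, and a methoxymethyl group would address that. On these data alone, how an aminomethyl group or a longer chain would compare also remains open.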